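A few compounds are considered here, and "the series" means these few. Any claim that something is new, unique, unknown or untested is made for them only; others in the source may bear on it.

Measured so far: in a functional assay on NCI-H460 cells (Homo sapiens) for cytotoxicity, read by MTT assay, with a stated time of 72 h (on this read-out higher numbers stand for weaker inhibition and lower numbers for stronger inhibition), compound 1 `COc1cc2c(Oc3ccc(NC(=O)c4nn(-c5ccccc5F)c(=O)c5ccccc45)cc3F)ccnc2cc1OCCCN1CCN(C)CC1` gives 230 nM, and compound 2 `COc1cc2c(Oc3ccc(NC(=O)c4nn(-c5ccc([N+](=O)[O-])cc5)c(=O)c5ccccc45)cc3F)ccnc2cc1OCCCN1CCN(C)CC1` gives 980 nM.

For the measured compounds named here, compound 1 stands lowest of these two numbers; its only neighbour is compound 2, reached by a 4.3-fold higher number from compound 1 to compound 2 (0.63 log units; beyond the scatter). Compound 3 `COc1cc2c(Oc3ccc(NC(=O)c4nn(-c5ccccc5F)c(=O)c5ccccc45)cc3F)ccnc2cc1OCCCN1CCC(C)CC1` keeps everything else of compound 1 and differs only by 4-methylpiperidin-1-yl in place of 4-methylpiperazin-1-yl on a saturated chain carbon, three bonds along the chain from an oxygen on an aromatic ring. Going by the values given here, the one measured step alters a group on an aromatic nitrogen, far from this place, so no measured step bears on the change in hand. With nothing to guide it, the expected step of a 1.3-fold higher number from compound 1 to compound 3 (0.12 log units; within the scatter) is none beyond the scatter. Compound 3 is therefore estimated at 300 nM, in a range from 90 nM to 1000 nM.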

Compound 3, half-maximal inhibitory concentration: 200 nM
For compound 3 the middle estimate is 1.5-fold (0.18 log units) above the measured one, within the range that was stated.
By their numbers in this assay, from the lowest: compounds 3 and 1 (each within the scatter of the next); then compound 2.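

Compound 1 and compound 3 differ only at the end of the chain, where 4-methylpiperidin-1-yl replaces 4-methylpiperazin-1-yl. In this assay this exchange gives a 1.2-fold lower number from compound 1 to compound 3 (0.06 log units; within the scatter), so the two compounds cannot be told apart, and the second ring nitrogen of compound 1 is not needed for a number in this range. No available evidence explains this result. Still open, on these data alone, is how morpholin-4-yl or an open dimethylamino group would read at this place. As far as these compounds go, a longer chain carrying 4-methylpiperidin-1-yl also remains open.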